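The source may report more compounds than this note shows. Statements on the series, on what has been measured and on what is new or still open speak of the compounds shown alone.

Compound 3, `Cc1cc(NCc2ccccn2)n2ncc(-c3c(C)cccc3C)c2n1`, carries a 2,6-dimethylphenyl group on the shared core. In a physicochemical assay for solubility, read by HPLC, using the shake flask method, measured as kinetic solubility, with a stated time of 2 h, at pH 7.4 (on this read-out lower numbers stand for lower solubility and higher numbers for higher solubility), compound 3 gives < 5000 nM, which is a limit of the assay and not a number. Its two measured neighbours are compound 1, `Cc1cc(NCc2ncc[nH]2)n2nc(C)c(-c3ccccc3)c2n1`, and compound 2, `Cc1cc(NCc2ccccn2)n2ncc(-c3ccccc3C)c2n1`. In this assay compound 1 gives < 5000 nM, likewise a limit. In this assay compound 2 gives < 5000 nM, again a limit. Among the measured compounds shown here, the one step between compounds that differ in a single place, a step that the two limits leave unreadable from compound 2 to compound 3, cannot be sized because the limit of < 5000 nM in this assay, at which 3 of the 3 values shown sit, leaves no readable number on either side of it.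

Compound 4, `Cc1cc(NCc2ccccn2)n2ncc(-c3cncnc3)c2n1`, differs from compound 3 in one place: pyrimidin-5-yl in place of 2,6-dimethylphenyl on an aromatic carbon. For the measured compounds named here, none of the measured steps bears on this exchange, and the single step on hand gives neither direction nor size, so the series itself supplies no expectation of change beyond the scatter. Compound 4 is estimated at 8000 nM in this assay, with a range from 2000 nM to 40000 nM. Going by the values given here, the step this estimate means, an at least 1.6-fold higher number from compound 3 to compound 4 (0.20 log units; that floor lies within the scatter), is an expectation resting on no measured step, and the read-out may again be reported only as a limit.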

Compound 4, solubility: 111000 nM
For compound 4 the middle estimate is 14-fold (1.14 log units) below the measured one, outside the stated range (above it).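

In this assay, pyrimidin-5-yl in place of 2,6-dimethylphenyl on the aromatic carbon of the five-membered ring gives an at least 22-fold higher number from compound 3 to compound 4 (1.34 log units; beyond the scatter), and pyrimidin-5-yl in place of 2-methylphenyl at the same place gives an at least 22-fold higher number from compound 2 to compound 4 (1.34 log units; beyond the scatter). Among the compounds shown here, these are the first steps with a readable direction, and they show that the group on this carbon can carry the read-out clear of the limit, which the methyl exchange between the two aryl groups could not show. Both steps are floors and not full sizes, because each starts from a limit: the limit of < 5000 nM in this assay, at which 3 of the 4 values shown sit.

The exchange replaces a carbon-only ring bearing methyl groups with a ring holding 2 hetero atoms and 2 hydrogen-bond acceptors, and the compounds shown do not separate the loss of the methyl groups from the entry of the ring nitrogens. On these data alone, it also remains open whether an unsubstituted phenyl, a pyridin-3-yl or a phenyl ring carrying an amine at this place would give a number rather than a limit, and how large the true step from either methylated compound is.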